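A few compounds are considered here, and "the series" means these few. Any claim that something is new, unique, unknown or untested is made for them only; others in the source may bear on it.

Among the compounds with values here, compound 1 `NC1=NC2(CCOCC2)N(OCCCOc2ccc(F)cc2)C(N)=N1` is one of two compounds measured in an assay on isolated protein for inhibition of Dihydrofolate reductase (Homo sapiens), read by spectrophotometry, using NADPH, with stated times of 5 s and 6 min; a higher number here means a weaker inhibitor, a lower number a stronger inhibitor. In this assay compound 1 gives 46.6 nM, the highest of the two numbers recorded, while compound 2 `NC1=NC2(CCSCC2)N(OCCCOc2ccc(Cl)cc2)C(N)=N1` gives 18.3 nM; the two differ in more than one place, so their values are only set side by side here. The next compound, compound 3 `NC1=NC2(CCOCC2)N(OCCCOc2ccc(Cl)cc2Cl)C(N)=N1`, carries 2,4-dichlorophenyl in place of 4-fluorophenyl on an oxygen on a saturated carbon. Within the data shown here, no measured pair shows this single change, so the expected step from compound 1 to compound 3 is a moderate one toward a lower number, a 1.9-fold lower number from compound 1 to compound 3 (0.27 log units; within the scatter). On that basis compound 3 is expected to give about 25 nM, with a range from 9 nM to 70 nM.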

Compound 3, half-maximal inhibitory concentration: 7.46 nM
Estimate against measurement, compound 3: 3.4-fold (0.53 log units) above; the whole stated range lies above it.
By their numbers in this assay, from the lowest: compound 3; then compound 2; then compound 1.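

In this assay, 2,4-dichlorophenyl in place of 4-fluorophenyl on an oxygen on a saturated carbon gives a 6.2-fold lower number from compound 1 to compound 3 (0.80 log units; beyond the scatter) and lies beyond the scatter. Within the data shown here, this is the first single change that can be read here, and it shows that the aromatic group at the end of the chain alters the number while the rest of compound 1 stays fixed. No evidence given here explains the step. The compounds shown leave open how much of the step belongs to each chlorine, and how a plain phenyl or a longer chain would read at this place.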